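Removing one methyl group from compound 3

The source may hold more compounds than are shown below. What is called first, only, known or untested is meant among the compounds shown, and "the series" means these compounds.

Measured so far in a toxicity assay on Vero cells (Chlorocebus sabaeus) for cytotoxicity, with a stated time of 48 h; on this read-out higher numbers stand for lower toxicity in this test and lower numbers for higher toxicity in this test:
- compound 1 `C=C1CC[C@@H]2[C@](C)(CO)[C@H](O)CC[C@@]2(C)[C@@H]1C/C=C1/C(=O)OC[C@H]1Oc1c(Cl)cc(Cl)c2cccnc12`: 82500 nM
- compound 2 `C=C1CC[C@@H]2[C@](C)(CO)[C@H](O)CC[C@@]2(C)[C@@H]1C/C=C1/C(=O)OC[C@H]1Oc1cccnc1[N+](=O)[O-]`: 37700 nM
- compound 3 `C=C1CC[C@@H]2[C@](C)(CO)[C@H](O)CC[C@@]2(C)[C@@H]1C/C=C1/C(=O)OC[C@@H]1Oc1cccc2ccc(C)nc12`: 99800 nM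

Compound 3 at 99800 nM lies within the usual scatter of compound 1, and the lower number of compound 2 lies beyond the scatter from both. Compound 4 `C=C1CC[C@@H]2[C@](C)(CO)[C@H](O)CC[C@@]2(C)[C@@H]1C/C=C1/C(=O)OC[C@@H]1Oc1cccc2cccnc12` is compound 3 with one small edit: hydrogen in place of methyl on an aromatic carbon. In words, this is hydrogen in place of methyl on an aromatic carbon, next to the ring nitrogen.

Going by the values given here, no measured step isolates this change. Among the compounds with values here, the only single-place step, a 2.2-fold lower number from compound 1 to compound 2 (0.34 log units; beyond the scatter), exchanges a whole 5,7-dichloroquinolin-8-yl group for 2-nitropyridin-3-yl, and even that edit is modest. The present edit is far smaller, so no shift beyond the scatter is expected in this assay. The expected result is a 1.1-fold lower number from compound 3 to compound 4 (0.04 log units; within the scatter), which would be no real change. For compound 4 the estimate is 90000 nM, with an expected range of 48000 nM to 170000 nM.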

Compound 4, half-maximal cytotoxic concentration: 20800 nM
The estimate for compound 4 lay 4.3-fold (0.64 log units) above the measured number, and the stated range ends above it.
By their numbers in this assay, from the lowest: compounds 4 and 2 (each within the scatter of the next); then compounds 1 and 3 (each within the scatter of the next).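

In this assay, the methyl on the aromatic carbon next to the ring nitrogen turns out to matter: going from 2-methylquinolin-8-yl to quinolin-8-yl gives a 4.8-fold lower number from compound 3 to compound 4 (0.68 log units; beyond the scatter), which here means higher toxicity in this test. Losing this single heavy atom therefore moves the number further than exchanging a whole group does in a 2.2-fold lower number from compound 1 to compound 2 (0.34 log units; beyond the scatter), so the size of an edit is a poor guide to the size of its step at this position. Nothing available explains why this small edit has such an effect.

Still open, on these data alone, is how an ethyl group, a chlorine atom, an amine or a longer chain at this same carbon would compare with methyl and hydrogen. As far as these compounds go, it is also open whether adding a methyl at this place would shift the number of compound 1 in a similar way.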